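Thiazole Amide in Place of Furylmethyl Amide

The compounds below may be only part of what the source reports. "The series", "measured", "known", "first", "only" and "open" are said of these compounds alone.

compound 1, `COCOc1cc(/C=C/C(=O)OCC(=O)NCc2ccco2)ccc1OCc1ccccc1`: 300 nM
compound 2, `CCOc1ccc(COc2c(OC)cc(/C=C/C(=O)OCC(=O)Nc3ccccc3)cc2OC)cc1`: > 200000 nM

Among the compounds with values here, in a functional assay on K562 cells (Homo sapiens) for cytotoxicity, read by MTT assay, with a stated time of 72 h (a higher number here means a weaker inhibitor, a lower number a stronger inhibitor), compound 1 gives 300 nM, the only number measured here. Compound 2 sits at the limit of > 200000 nM in this assay, at which 1 of the 2 values shown sits, a limit of the assay and not a number. Compound 3, `COCOc1cc(/C=C/C(=O)OCC(=O)Nc2nccs2)ccc1OCc1ccccc1`, differs from compound 1 by 1,3-thiazol-2-yl in place of (furan-2-yl)methyl on an amide-type nitrogen. Within the data shown here, no measured step of this kind is available, so the size of the change rests on expectation alone. The step of a 5.0-fold higher number from compound 1 to compound 3 (0.70 log units; beyond the scatter) is expected to weaken the inhibitor by more than the usual scatter. Compound 3 is estimated at 1500 nM, between 300 nM and 20000 nM.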

Compound 3, half-maximal inhibitory concentration: > 200000 nM
Compound 3 ended at the assay's limit (the forecaster's own chance of this, stated with the estimate: 15%); middle value at least 130-fold (2.12 log units) from the limit.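

In this assay, putting 1,3-thiazol-2-yl in place of (furan-2-yl)methyl on the amide-type nitrogen gives an at least 660-fold higher number from compound 1 to compound 3 (2.82 log units; beyond the scatter). With the rest of compound 1 unchanged, the shared core alone does not secure cytotoxicity, and the group on this nitrogen decides whether it is seen at all. For compound 3 the value is a limit of the assay and not a number, so the true size of the step stays unknown: the limit of > 200000 nM in this assay, at which 2 of the 3 values shown sit.

As far as these compounds go, it remains open whether (1,3-thiazol-2-yl)methyl, benzyl or plain furan-2-yl on this nitrogen would keep the activity of compound 1.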